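The source may report more compounds than this note shows. Statements on the series, on what has been measured and on what is new or still open speak of the compounds shown alone.

Compound 1 `CCSCCC12CCC(c3nnc(-c4ccccc4C(F)(F)F)n3C)(CC1)CC2`: 79%
Compound 2 `Cn1c(-c2ccccc2C(F)(F)F)nnc1C12CCC(CCS(=O)(=O)C(C)(C)C)(CC1)CC2`: 65%
Compound 3 `CCS(=O)(=O)CCC12CCC(c3nnc(-c4ccccc4Br)n3C)(CC1)CC2`: 86%

Of the compounds shown here, three sharing one core have been tested in a functional assay on the whole organism (strain ICR) for inhibition, with Mus musculus as the target, with a stated time of 4 h, at a dose of 10 mg/kg by the oral route; on this read-out lower numbers stand for less inhibition and higher numbers for more inhibition at the one dose given (going by the name of the read-out). Compound 2 gives the lowest of the three numbers: compound 1 lies above it beyond the scatter, and compound 3 lies furthest above it, also beyond the scatter. Compound 4 `CCS(=O)(=O)CCCCC12CCC(c3nnc(-c4ccccc4C(F)(F)F)n3C)(CC1)CC2` is not yet measured. It differs from compound 2 by a rearrangement of the same atoms: 2-(ethylsulfonyl)ethyl in place of (tert-butyl)sulfonyl on a saturated chain carbon, two bonds along the chain from a saturated ring carbon.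

For the measured compounds named here, one measured step bears on this change. The step of a number 14 percentage points lower from compound 1 to compound 2 (beyond the scatter) shows that putting (tert-butyl)sulfonyl in place of ethylsulfanyl lowered the number in this assay by a modest amount. Compound 4 removes that group and instead carries an ethylsulfonyl chain, as compound 3 does, which lies furthest above compound 2. Going by the values given here, no measured pair shows the effect of lengthening the chain itself, so the expectation is uncertain. Compound 4 is therefore expected to show a rise, a number 13 percentage points higher from compound 2 to compound 4 (beyond the scatter). Compound 4 is estimated at 78%, within a range of 62% to 90%.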

Compound 4, a percentage reported as inhibition, in the whole organism at one dose (the size of the read-out at that dose, not a potency): 90%
Estimate against measurement, compound 4: 12 percentage points below; measured number inside the range.
By their numbers in this assay, from the lowest: compound 2; then compounds 1, 3 and 4 (each within the scatter of the next, the first and the last beyond it).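

In this assay, a number 25 percentage points higher from compound 2 to compound 4 (beyond the scatter), so at this position the outcome depends on how the atoms are joined and not only on which atoms are present, since 2-(ethylsulfonyl)ethyl and (tert-butyl)sulfonyl have the same heavy-atom count. Replacing ethylsulfanyl at the same place can also move the number in either direction: (tert-butyl)sulfonyl lowered it earlier, whereas 2-(ethylsulfonyl)ethyl gives a number 11 percentage points higher from compound 1 to compound 4 (beyond the scatter). Nothing measured here explains this difference between the two groups.

This single change alters both the group on the sulfonyl and how far along the chain the sulfonyl sits, so the two contributions cannot be separated. Going by these compounds, it also remains open how the number would respond to a longer chain, or to a carboxylic acid or an amine in the same place.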